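The compounds below may be only part of what the source reports. "The series", "measured", "known", "first", "only" and "open" are said of these compounds alone.

Compound 1 `COc1cccc(C(=O)N2CCN(CC(=O)N3CCN(CCCc4c[nH]c5ccccc45)CC3)CC2)c1` gives > 200000 nM in an ADME assay on SH-SY5Y cells (Homo sapiens) for cytotoxicity, read by MTT assay, with a stated time of 72 h (a higher number here means a weaker inhibitor, a lower number a stronger inhibitor), which is a limit of the assay. Compound 2 `O=C(CN1CCN(C(=O)c2cccc(F)c2)CC1)N1CCN(CCCc2c[nH]c3ccccc23)CC1` gives 165000 nM in this assay. Compound 3 `O=C(CN1CCN(C(=O)c2ccccc2)CC1)N1CCN(CCCc2c[nH]c3ccc(F)cc23)CC1` gives 146000 nM in this assay.

From compound 2 to compound 1 the change is methoxy in place of fluoro on an aromatic carbon, and it made an at least 1.2-fold higher number from compound 2 to compound 1 (0.08 log units; that floor lies within the scatter); the size of that step is bounded by the limit of > 200000 nM in this assay, at which 1 of the 3 values shown sits. Compound 3 and compound 2 share their atoms joined differently, and the difference between the two cores is not broken down here. Compound 4 `COc1ccc2[nH]cc(CCCN3CCN(C(=O)CN4CCN(C(=O)c5ccccc5)CC4)CC3)c2c1` arises from compound 3 by methoxy in place of fluoro on an aromatic carbon, the same kind of change, though here the place is part of a fused or bridged system of two rings, meta to a fused ring and para to a fused ring, rather than meta to a large group. Compound 4 is expected to give 175000 nM. This rests on compound 3 at 146000 nM and on the earlier step, so the expected change is a 1.2-fold higher number from compound 3 to compound 4 (0.08 log units; within the scatter).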

Compound 4, half-maximal inhibitory concentration: > 200000 nM
Compound 4: no number, only a limit (the forecaster's own chance of this, stated with the estimate: 30%); middle value at least 1.1-fold (0.05 log units) from the limit.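

Carried to a second core, methoxy in place of fluoro gave an at least 1.3-fold higher number from compound 3 to compound 4 (0.13 log units; that floor lies within the scatter) in this assay. Compound 4 gives > 200000 nM, which is a limit of the assay and not a number: the limit of > 200000 nM in this assay, at which 2 of the 4 values shown sit. This shows that the change can be read on both cores only as a floor, and it does not show whether the step keeps its size from one core to the other: the same change on two cores in this assay, an at least 1.2-fold higher number (0.08 log units; that floor lies within the scatter) from compound 2 to compound 1 and an at least 1.3-fold higher number (0.13 log units; that floor lies within the scatter) from compound 3 to compound 4; the limit leaves it open whether they differ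

The compounds shown leave open how a chloro group, a hydroxyl group or an amine on this aromatic carbon would read in this assay. They also leave open what a longer chain in place of the propyl linker to the indole would do.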